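Acid to Morpholine Amide on a Cinnamate Series

The source may hold more compounds than are shown below. What is called first, only, known or untested is meant among the compounds shown, and "the series" means these compounds.

Measured compounds:
compound 1, `NNC(=O)COc1ccncc1-c1ccc2ccccc2c1` — "not determined" (no result reported) in an assay on a protein complex for inhibition of CDK8/Cyclin C (Homo sapiens), with a stated time of 1 h; on this read-out lower numbers stand for stronger inhibition and higher numbers for weaker inhibition
compound 2, `O=C(O)/C=C/c1ccncc1-c1ccc2ccccc2c1` — 5 nM in this assay

For the measured compounds named here, compound 2 is the only compound with a number in this assay; compound 1 has no result there, so compound 2 stands alone and no comparison between measured compounds is available. Compound 3, `O=C(/C=C/c1ccncc1-c1ccc2ccccc2c1)N1CCOCC1`, follows from compound 2 by the change (morpholin-4-yl in place of hydroxy on a carbonyl carbon). Going by the values given here, with no measured step to lean on, the expectation rests on the structural change alone: the carboxy group of compound 2 is replaced by a (morpholin-4-yl)carbonyl group, and a moderate loss, somewhat beyond the usual scatter, is expected in this assay. Compound 3 is therefore estimated at 20 nM, with a range from 4 nM to 100 nM. This estimate means a step of a 4.0-fold higher number from compound 2 to compound 3 (0.60 log units; beyond the scatter), expected rather than measured.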

Compound 3, half-maximal inhibitory concentration: 60.3 nM
Compound 3: the middle estimate sits 3.0-fold (0.48 log units) below what was measured, and the stated range covers the measured number.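

In this assay, for the compounds shown here, morpholin-4-yl in place of hydroxy on the carbonyl carbon gives a 12-fold higher number from compound 2 to compound 3 (1.08 log units; beyond the scatter), the first measured step. It shows that this position responds strongly to the change from carboxy to (morpholin-4-yl)carbonyl, although inhibition is not abolished, as compound 3 still gives 60.3 nM in this assay. Nothing measured here accounts for the size of the step.

Going by these compounds alone, the single step cannot separate the loss of the hydroxy from the arrival of the morpholine ring, so it remains open how a methyl ester, a primary amide or a piperidin-1-yl amide on the same carbonyl carbon would read. As far as these compounds go, it also remains open whether a step of this size would recur with a longer chain carrying the carboxylic acid or the morpholine amide.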